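Stability of an Acrylamide Series Under a Change of Amide

The compounds below may be only part of what the source reports. "The series", "measured", "known", "first", "only" and "open" are said of these compounds alone.

This set of compounds shares a common core carrying an acrylamide and a bromine-bearing ring system, and the compounds differ in the amide attached to that ring system. Compound 1 `C=CC(=O)N1CC(NC(=O)Cn2cc(C(=O)N3CCc4ccccc4C3)c3cc(Br)ccc32)C1` and compound 2 `C=CC(=O)N1CC(NC(=O)Cn2c(C3CC3)c(C(=O)N3CCc4c(cccc4OC)C3)c3cc(Br)ccc32)C1` have both been measured in a physicochemical assay for pharmacokinetics, read by LC-MS, in phosphate buffer, at pH 7.4, in the presence of a further agent that is not named here; a higher number here means that the compound lasts longer, a lower number that the compound disappears faster. In this assay compound 1 gives 1.67 h, and compound 2 gives 1.67 h. The two values are level at the digits shown, and the gap between them lies within the usual scatter, so no order can be read from them. Compound 3 `C=CC(=O)N1CC(NC(=O)Cn2cc(C(=O)NCc3ccccc3)c3cc(Br)ccc32)C1` has not yet been measured. It differs from compound 1 in one place (benzylamino in place of 1,2,3,4-tetrahydroisoquinolin-2-yl on a carbonyl carbon). For the measured compounds named here, no step between measured compounds of this kind is available, so the effect of this change rests on expectation alone. Since the two measured compounds sit level despite differing on several fronts, the change from compound 1 to compound 3 is expected to move the half-life by no more than the scatter, giving an expected step of a 1.0-fold higher number from compound 1 to compound 3 (0.01 log units; within the scatter). Compound 3 is therefore estimated at 1.7 h, within a range from 0.9 h to 3.3 h.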

Compound 3, half-life: 1.67 h
The estimate for compound 3 lay 1.0-fold (0.01 log units) above the measured number, and the stated range covers the measured number.
By their numbers in this assay, from the lowest: compounds 1, 2 and 3 (each within the scatter of the next).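

In this assay, for the compounds shown here, replacing 1,2,3,4-tetrahydroisoquinolin-2-yl with benzylamino on a carbonyl carbon gives no change at the digits printed from compound 1 to compound 3 (within the scatter), and this is the first reading tied to a single place, as compound 1 and compound 2 differ in more than one. At this position, the half-life therefore stays level through this exchange, even though the non-aromatic ring leaves and the entering benzylamino group brings a hydrogen-bond donor that the leaving group lacks. Nothing available explains why the half-life stays level, and this single step cannot show how the compounds disappear in this test.

As far as these compounds go, whether the position tolerates every change remains open: an amine or a carboxylic acid in the group on this carbonyl carbon, or a longer chain in place of benzylamino, could behave differently. The acrylamide is the same in all three compounds, leaving open how the half-life would respond if that group were replaced by a saturated propanoyl group.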